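Ester alkyl enlargement on the lowest-ranked member of the series

This account rests on a few compounds, and the source may have more. Where it says the series, first, only, none or still open, it means among the compounds named here.

Compound 2 `CO/C(O)=C1\C(C)=NC(C)=C([N+](=O)[O-])C1c1ccncc1` gives 48500 nM in a functional assay (cardiac atrium) for agonist activity, with Cavia porcellus as the target (a lower number here means that less compound is needed, a higher number that more compound is needed for the effect), the highest of the three numbers measured. Compound 1 `CC1=NC(C)=C([N+](=O)[O-])C(c2ccccn2)/C1=C(\O)OC1CCCC1` gives 19800 nM, and compound 3 `CC1=NC(C)=C([N+](=O)[O-])C(c2ccccn2)/C1=C(\O)OCC(C)C` gives 9100 nM, the lowest number of the set; both differ from compound 2 elsewhere in the structure as well, so neither gap is a single-point step.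

Compound 4 `CC1=NC(C)=C([N+](=O)[O-])C(c2ccncc2)/C1=C(\O)OC1CCCCC1` is the untested analogue of compound 2 with cyclohexyl in place of methyl on an oxygen on an unsaturated carbon. Going by the values given here, the only measured step at the same place is a 2.2-fold lower number from compound 1 to compound 3 (0.34 log units; beyond the scatter), a change between two larger alkyl groups on that oxygen, so the methyl-to-cyclohexyl change has no direct precedent among the measured compounds. That step does show the ester alkyl moving the number by a modest amount, and the two larger-alkyl compounds 1 and 3 both sit at lower numbers than the methyl compound 2, although they are not pure single-point comparisons.

A modest move toward a lower number is therefore expected for compound 4, estimated at 20000 nM with a range of 6000 nM to 60000 nM, which corresponds to an expected step of a 2.4-fold lower number from compound 2 to compound 4 (0.38 log units; beyond the scatter) in this assay.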

Compound 4, half-maximal effective concentration: 4940 nM
Compound 4: the middle estimate sits 4.0-fold (0.61 log units) above what was measured; the whole stated range lies above it.
By their numbers in this assay, from the lowest: compounds 4 and 3 (each within the scatter of the next); then compound 1; then compound 2.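

Cyclohexyl in place of methyl on an oxygen on an unsaturated carbon gives a 9.8-fold lower number from compound 2 to compound 4 (0.99 log units; beyond the scatter) in this assay, the first single-place reading that starts from the methyl ester end of the series. Going by these compounds alone, the position therefore accepts the six-membered carbon ring without any loss, and the number falls further here than in a 2.2-fold lower number from compound 1 to compound 3 (0.34 log units; beyond the scatter), the only other step measured at this oxygen, so the choice of alkyl group can matter more than the exchange of cyclopentyl for isobutyl suggested. No measurement at hand bears on why the number falls with this change.

Still open, going by these compounds, is how the number runs between methyl and cyclohexyl, and beyond them: ethyl, a longer chain such as n-hexyl, or benzyl on the same oxygen would show whether it follows the size of the group or is particular to the cyclohexyl ring. Also open, on these data alone, is whether a step of this size holds on the core of compound 1, since the two measured steps at this oxygen start from different cores and different alkyl groups.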